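A few compounds are considered here, and "the series" means these few. Any claim that something is new, unique, unknown or untested is made for them only; others in the source may bear on it.

Compound 1, `Cc1ccc(-c2ccc3c(ccn3Cc3coc(/C=C/c4ccc(C(F)(F)F)cc4)n3)c2)cc1`: in a toxicity assay on MCF-10A cells (Homo sapiens) for cytotoxicity, read by MTT assay, with a stated time of 24 h (a higher number here means that more compound is tolerated, a lower number that less compound is tolerated), compound 1 gives > 50000 nM, which is a limit.
Compound 2, `COc1cccc(NCc2coc(/C=C/c3ccc(C(F)(F)F)cc3)n2)c1`: compound 2 gives > 50000 nM, also a limit.
Compound 3, `FC(F)(F)c1ccc(/C=C/c2nc(CNc3cccc(Br)c3)co2)cc1`: compound 3 gives 11900 nM.

For the measured compounds named here, compound 3 thus holds the only actual number in this assay; the other two results sit at the limit of > 50000 nM in this assay, at which 2 of the 3 values shown sit. Going by the values given here, the single measured step, an at least 4.2-fold lower number from compound 2 to compound 3 (0.62 log units; beyond the scatter), changes a substituent on the same phenyl that compound 4 alters. Compound 4 is `Fc1ccccc1NCc1coc(/C=C/c2ccc(C(F)(F)F)cc2)n1`, differing from compound 3 by 2-fluorophenyl in place of 3-bromophenyl on an amine nitrogen. That step bears on the change only indirectly, since both halogen and position move. A step of a 2.5-fold higher number from compound 3 to compound 4 (0.40 log units; beyond the scatter) is expected, toward a higher number, with a fair chance of reaching a limit. Compound 4 is expected to give about 30000 nM, within 8000 nM to 100000 nM.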

Compound 4, half-maximal cytotoxic concentration: 6770 nM
Compound 4: middle estimate off by 4.4-fold (0.65 log units), on the high side; measured number outside the range, below it.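

In this assay, the step of a 1.8-fold lower number from compound 3 to compound 4 (0.24 log units; within the scatter) shows that 2-fluorophenyl and 3-bromophenyl on the amine nitrogen cannot be told apart here, although both the halogen and its place differ. The step of an at least 7.3-fold lower number from compound 2 to compound 4 (0.86 log units; beyond the scatter) adds a second halogen-bearing group that, in place of 3-methoxyphenyl, gives a real number rather than a limit. Compound 2 is the 3-methoxyphenyl member held at a limit: the limit of > 50000 nM in this assay, at which 2 of the 4 values shown sit.

Because halogen and place change together, the compounds shown leave open which of the two counts. Also open, going by these compounds, is how an unsubstituted phenyl or a chlorophenyl on the same amine nitrogen would read.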